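Swapping methoxy for methyl on the triazolethione aryl group

A few compounds are considered here, and "the series" means these few. Any claim that something is new, unique, unknown or untested is made for them only; others in the source may bear on it.

Measured compounds:
compound 1, `COc1ccc(-n2c(Nc3nc(-c4ccc([N+](=O)[O-])cc4)cs3)n[nH]c2=S)cc1`, 100 mg/kg
compound 2, `COc1ccccc1-n1c(Nc2nc(-c3ccc([N+](=O)[O-])cc3)cs2)n[nH]c1=S`, 100 mg/kg
compound 3, `COc1ccccc1-n1c(Nc2nc(-c3ccc(Br)cc3)cs2)n[nH]c1=S`, 300 mg/kg

In a functional assay on the whole organism (strain Swiss albino) for inhibition, with Mus musculus as the target, with a stated time of 0.5 h (on this read-out lower numbers stand for an effect already at smaller amounts and higher numbers for an effect only at larger amounts of compound), compound 3 gives 300 mg/kg, the highest number among the three measured compounds; compound 1 and compound 2 both sit lower, and a 3.0-fold higher number from compound 2 to compound 3 (0.48 log units; beyond the scatter) shows that gap as a modest step beyond the scatter. Compound 4, `Cc1ccccc1-n1c(Nc2nc(-c3ccc(Br)cc3)cs2)n[nH]c1=S`, differs from compound 3 by methyl in place of methoxy on an aromatic carbon.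

Neither measured step touches this position in the same way. no change at the digits printed from compound 1 to compound 2 (within the scatter) concerned where the methoxy sits rather than whether it is present, and a 3.0-fold higher number from compound 2 to compound 3 (0.48 log units; beyond the scatter) concerned the group on the other aryl ring. So there is no direct precedent for a methyl in place of a methoxy here, and the change is small in what is counted. On that basis no step beyond the scatter is expected in this assay from compound 3 to compound 4, and no change at the digits printed from compound 3 to compound 4 (within the scatter) expresses that expectation. Compound 4 is therefore estimated at 300 mg/kg, within a range from 100 mg/kg to 1000 mg/kg.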

Compound 4, minimum effective dose: 30 mg/kg
For compound 4 the middle estimate is 10-fold (1.00 log units) above the measured one; the whole stated range lies above it.
By their numbers in this assay, from the lowest: compound 4; then compounds 1 and 2 (each within the scatter of the next); then compound 3.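

In this assay, exchanging 2-methoxyphenyl for 2-methylphenyl gives a 10-fold lower number from compound 3 to compound 4 (1.00 log units; beyond the scatter), so the group carried on this aromatic carbon can move the dose needed for an effect beyond the scatter. The earlier comparison of the aryl group, no change at the digits printed from compound 1 to compound 2 (within the scatter), moved the methoxy around the ring and left the number unchanged; this step replaces the methoxy itself and shows that the read-out responds to that exchange. No measurement available here accounts for the shift.

The compounds shown leave open whether the methyl would have the same effect with the nitro group of compound 2 on the other aryl ring in place of the bromo. They also leave open how an ethyl, a chloro or an amine at this place would compare with the methyl of compound 4.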